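The source may hold more compounds than are shown below. What is called first, only, known or untested is meant among the compounds shown, and "the series" means these compounds.

Working notes on the series, read in an ADME assay on microsomes from liver (Rattus norvegicus) for metabolic stability; on this read-out higher numbers stand for a longer-lived compound and lower numbers for a shorter-lived compound. Compound 1 `CC(C)[C@@H](c1ccc(-c2ccc3cccc(F)c3c2)[nH]c1=O)[C@@H]1OC(=O)NC1=O` gives 1.27 h, the lower of the two numbers in hand. Compound 2 `O=C1NC(=O)/C(=C/C(Cc2ccccc2)c2ccc(-c3ccc4cccc(F)c4c3)[nH]c2=O)O1` gives 2.96 h, a gap beyond the usual scatter. The next compound to be read is compound 3 `CC(C)[C@H](C[C@H]1SC(=O)NC1=O)c1ccc(-c2ccc3cccc(F)c3c2)[nH]c1=O`, and its change from compound 1 is (2,4-dioxo-1,3-thiazolidin-5-yl)methyl in place of 2,4-dioxo-1,3-oxazolidin-5-yl on a saturated chain carbon bound to an aromatic carbon and a saturated chain carbon. The core of compound 1 stays in place. Among the compounds with values here, no measured pair differs in one place only, so nothing shows directly what this swap does to the half-life. The expectation is therefore loose: a small upward move that stays within the scatter, leaning towards compound 2 at 2.96 h. The expected change is a 1.4-fold higher number from compound 1 to compound 3 (0.15 log units; within the scatter). For compound 3 the estimated half-life is 1.8 h, with an expected range of 0.7 h to 4.5 h.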

Compound 3, half-life: 0.143 h
Beside the measured number, compound 3's estimate is 13-fold (1.10 log units) above it, outside the stated range (below it).
By their numbers in this assay, from the lowest: compound 3; then compound 1; then compound 2.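

In this assay, the place on a saturated chain carbon bound to an aromatic carbon and a saturated chain carbon proves sensitive: with the core of compound 1 kept, (2,4-dioxo-1,3-thiazolidin-5-yl)methyl in place of 2,4-dioxo-1,3-oxazolidin-5-yl gives an 8.9-fold lower number from compound 1 to compound 3 (0.95 log units; beyond the scatter) on this single change. The entering group differs in two ways at once, sulfur for oxygen in the ring and an added methyl link, while ring size and the counted hydrogen-bond donors and acceptors stay the same, and this one step cannot divide the loss between the two. Nothing available explains the drop.

Still open, from the compounds shown here alone, is how 2,4-dioxo-1,3-thiazolidin-5-yl set directly on the chain carbon, or (2,4-dioxo-1,3-oxazolidin-5-yl)methyl, would read. A carboxylic acid or an amine at this place also remains untested among the compounds shown.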